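A few compounds are considered here, and "the series" means these few. Any claim that something is new, unique, unknown or untested is made for them only; others in the source may bear on it.

Working notes on the series. Compound 1 `Cn1c(-c2cccnc2)nc2ccc(-c3ccccc3Cl)c(CN)c21` was run in an in vitro ADME assay on microsomes from liver (Homo sapiens) for metabolic stability (a lower number here means that the compound disappears faster, a higher number that the compound lasts longer), and gave 1.6 h. Compound 2 `Cn1cnc2ccc(-c3ccccc3CO)c(CN)c21` gives 1.67 h in this assay, and compound 3 `NCc1c(-c2ccc(Cl)cc2Cl)ccc2nc[nH]c12` gives 2.15 h. On these three numbers compound 1 sits at the low end, but its gaps to compound 2 and to compound 3 both fall within the usual scatter, so the three read as a single cluster rather than an order.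

Compound 4 `COCc1nc2ccc(-c3ccccc3Cl)c(CN)c2n1C` has not yet been measured in this assay. Against compound 1 it differs in one place: methoxymethyl in place of pyridin-3-yl on an aromatic carbon. Going by the values given here, no measured pair of this kind exists in the set, so nothing recorded speaks directly to the size of this step. What the set does show is that three different substituents on the shared core all return half-lives that sit together, which suggests a step of no size beyond the scatter. The step expected is a 1.1-fold higher number from compound 1 to compound 4 (0.03 log units; within the scatter). For compound 4 the estimate in this assay is 1.7 h, with a range from 0.9 h to 3.2 h.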

Compound 4, half-life: > 3.33 h
Compound 4 ended at the assay's limit (the forecaster's own chance of this, stated with the estimate: 5%); at least 1.9-fold (0.29 log units) between middle value and limit.
By their numbers in this assay, from the lowest: compounds 1, 2 and 3 (each within the scatter of the next). At a limit, above all of these: compound 4.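

In this assay, methoxymethyl in place of pyridin-3-yl on the aromatic carbon between two ring nitrogen atoms gives an at least 2.0-fold higher number from compound 1 to compound 4 (0.31 log units; beyond the scatter). Compound 4 stands at a limit of the assay and not at a number, so the step has a floor but no measured size: the limit of > 3.33 h in this assay, at which 1 of the 4 values shown sits. Going by these compounds alone, no pair among compounds 1, 2 and 3 differs in one place, so this is the first sign that the group at this position can move the half-life.

One pair cannot tell whether the step follows the loss of the pyridine ring, the oxygen of methoxymethyl or the lower heavy-atom count. A phenyl ring, which keeps the ring without its nitrogen, and a propyl chain, which has the length of methoxymethyl without its oxygen, would bear on this at the same position.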